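The source may report more compounds than this note shows. Statements on the series, on what has been measured and on what is new or still open speak of the compounds shown alone.

In a functional assay on CHO cells for agonist activity at Free fatty acid receptor 2 (Homo sapiens), read by cAMP accumulation (on this read-out higher numbers stand for larger maximal responses and lower numbers for smaller maximal responses), compound 1 `CC(C)[C@H](C(=O)NCc1ccccc1)c1ccc(Cl)cc1` reaches only a limit of the assay, < 30%. Compound 2 `CC(C)[C@H](C(=O)Nc1ccccc1)c1ccc(Cl)cc1`, with phenyl in place of benzyl on the amide-type nitrogen, likewise gives only a limit, < 30%. The step that the two limits leave unreadable from compound 1 to compound 2 is therefore not readable, and compound 2 stands at the limit of < 30% in this assay, at which 2 of the 3 values shown sit. For the measured compounds named here, the one compound with a readable number is compound 3 `CC(C)C(C(=O)Nc1ncccn1)c1ccc(Cl)cc1`, which in this assay gives 50%; no single-place step connects it to compound 2, so its value can only be set beside the others.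

Compound 4 `CC(C)[C@H](C(=O)Nc1nncs1)c1ccc(Cl)cc1` differs from compound 2 in one place: 1,3,4-thiadiazol-2-yl in place of phenyl on an amide-type nitrogen. Going by the values given here, no measured step covers this exchange, and the only step between measured compounds, from compound 1 to compound 2, gives no size. What remains is that compound 3, the other compound carrying a nitrogen-containing ring on the amide-type nitrogen, returns a number rather than a limit. Compound 4 is therefore expected to rise off the limit by an estimated a number at least 15 percentage points higher from compound 2 to compound 4 (beyond the scatter), to an estimated 45% with a range from 25% to 70%.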

Compound 4, largest response reached (reported as efficacy), in percent of the reference or control that the assay uses: 115%
Beside the measured number, compound 4's estimate is 70 percentage points below it; the measured number lies above the stated range.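

In this assay, 1,3,4-thiadiazol-2-yl in place of phenyl on the amide-type nitrogen gives a number at least 85 percentage points higher from compound 2 to compound 4 (beyond the scatter). The same ring in place of benzyl gives a number at least 85 percentage points higher from compound 1 to compound 4 (beyond the scatter), so this position, which had given no readable step between its two carbon-only groups, now shows that a single exchange there can change the maximal response greatly. The values for compound 1 and compound 2 are limits, so both steps are known only as minimum sizes: the limit of < 30% in this assay, at which 2 of the 4 values shown sit.

The compounds shown leave open which atoms of the 1,3,4-thiadiazol-2-yl ring matter for this response, since its sulfur and its ring nitrogens change together. From the compounds shown here alone, a 1,3,4-oxadiazol-2-yl or a thiazol-2-yl group on the same nitrogen would separate them, and how either would read here remains unknown.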